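A Hydroxy Group Added to Compound 3

The source may hold more compounds than are shown below. What is called first, only, known or untested is meant among the compounds shown, and "the series" means these compounds.

In a functional assay on KB cells (Homo sapiens) for antiproliferative activity, read by MTT assay, with a stated time of 72 h (on this read-out higher numbers stand for weaker inhibition and lower numbers for stronger inhibition), compound 1 (`COc1cc(-c2ccsc2-c2ccc3ccccc3c2)cc(OC)c1OC`) gives 3660 nM, compound 2 (`CCOC(=O)c1cc(-c2ccc(OC)cc2)c(-c2cc(OC)c(OC)c(OC)c2)s1`) gives 10200 nM, and compound 3 (`COc1ccc(-c2cc(C(=O)O)sc2-c2cc(OC)c(OC)c(OC)c2)cc1`) gives 8650 nM. Compound 3 thus stands within the scatter of compound 2 and above compound 1. Compound 4 (`COc1ccc(-c2cc(C(=O)O)sc2-c2cc(OC)c(OC)c(OC)c2)cc1O`) differs from compound 3 by one change, (hydroxy in place of hydrogen on an aromatic carbon), which turns 4-methoxyphenyl into 3-hydroxy-4-methoxyphenyl. For the measured compounds named here, the only measured step, a 1.2-fold lower number from compound 2 to compound 3 (0.07 log units; within the scatter), lies at a different place and offers no direct guide to hydroxy in place of hydrogen on an aromatic carbon. The estimated step is a 1.6-fold lower number from compound 3 to compound 4 (0.20 log units; within the scatter) in this assay, a modest expected move toward a lower number, not beyond the scatter. Compound 4 is estimated at 5500 nM, with an expected range of 1800 nM to 16000 nM.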

Compound 4, half-maximal inhibitory concentration: 21800 nM
Compound 4: the middle estimate sits 4.0-fold (0.60 log units) below what was measured; measured number outside the range, above it.
By their numbers in this assay, from the lowest: compound 1; then compounds 3 and 2 (each within the scatter of the next); then compound 4.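

In this assay, hydroxy in place of hydrogen on an aromatic carbon, ortho to a methoxy group, gives a 2.5-fold higher number from compound 3 to compound 4 (0.40 log units; beyond the scatter). Turning 4-methoxyphenyl into 3-hydroxy-4-methoxyphenyl therefore weakens inhibition, and this is the first single change among these compounds to move the number beyond the scatter. Nothing available explains this loss. Going by these compounds, whether an amine or a fluorine on the same carbon would shift the number in the same direction remains open. So does whether the hydroxy would have the same effect alongside the ethyl ester of compound 2.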